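Benzyl aryl variation in the bombesin receptor subtype-3 series

The compounds below may be only part of what the source reports. "The series", "measured", "known", "first", "only" and "open" are said of these compounds alone.

Compound 2 `Cc1ccc(Cc2cnc(CCc3ccc(-c4ccccc4C(=O)O)cc3)[nH]2)cc1` holds the lowest number of the two measured in an in vitro functional assay on cells for agonist activity at Bombesin receptor subtype-3 (Mus musculus), read by luminescence and calcium flux (a lower number here means that less compound is needed, a higher number that more compound is needed for the effect), at 162 nM. Its nearest neighbour is compound 1 `N#Cc1ccccc1Cc1cnc(CCc2ccc(-c3ccccc3C(=O)O)cc2)[nH]1`, which in this assay gives 642 nM; the step between them is a 4.0-fold lower number from compound 1 to compound 2 (0.60 log units; beyond the scatter), from a 4-methylphenyl in place of 2-cyanophenyl on a saturated chain carbon bound to an aromatic carbon. Compound 3 `O=C(O)c1ccccc1-c1ccc(CCc2ncc(Cc3cccc(F)c3)[nH]2)cc1` is the next member, not yet measured; it differs from compound 2 by 3-fluorophenyl in place of 4-methylphenyl on a saturated chain carbon bound to an aromatic carbon. For the measured compounds named here, the one measured step at this place shows that the aryl group here moves the number, and compound 2 sits at the favourable end of that step. Going by the values given here, a 3-fluorophenyl at this place has no precedent, so the direction is uncertain; a moderate rise in the number is expected, the estimated step being a 2.0-fold higher number from compound 2 to compound 3 (0.30 log units; within the scatter). Compound 3 is expected to give 320 nM in this assay, within a range of 120 nM to 850 nM.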

Compound 3, half-maximal effective concentration: 7.9 nM
Estimate against measurement, compound 3: 41-fold (1.61 log units) above, outside the stated range (below it).
By their numbers in this assay, from the lowest: compound 3; then compound 2; then compound 1.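

In this assay, replacing 4-methylphenyl with 3-fluorophenyl gives a 21-fold lower number from compound 2 to compound 3 (1.31 log units; beyond the scatter), a far larger step than the only one available before, so this position has much more range than compound 1 and compound 2 revealed. Across the three aryl groups on the shared core, the span reaches an 81-fold lower number from compound 1 to compound 3 (1.91 log units; beyond the scatter), which places 3-fluorophenyl at the favourable end of the set and 2-cyanophenyl at the unfavourable end. No available evidence bears on why the number falls this far.

The change from 4-methylbenzyl to 3-fluorobenzyl alters both the substituent and where it sits on the phenyl ring, and the compounds shown do not separate these two changes. Going by these compounds, it also remains open whether a chlorine or a methoxy group on that phenyl ring would keep the number this low.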